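Compound 3: a 2,4-difluorophenyl swap on a shared core

The source may report more compounds than this note shows. Statements on the series, on what has been measured and on what is new or still open speak of the compounds shown alone.

Compound 1 (`N#Cc1ccc(-c2cc(Cl)cn3c([N+](=O)[O-])c(CS(=O)(=O)c4ccccc4)nc23)cc1`) and compound 2 (`O=[N+]([O-])c1c(CS(=O)(=O)c2ccccc2)nc2c(-c3cccc(CO)c3)cc(Cl)cn12`) share one core and differ in a single aromatic group. In an ADME assay on HepG2 cells (Homo sapiens) for cytotoxicity, read by MTT assay, with a stated time of 72 h (on this read-out lower numbers stand for higher toxicity in this test and higher numbers for lower toxicity in this test), compound 1 gives > 3900 nM, which is a limit and not a number. Compound 2 gives > 25000 nM, which is also a limit. Compound 2 therefore has no measured number to fix where it stands.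

Compound 3 (`O=[N+]([O-])c1c(CS(=O)(=O)c2ccccc2)nc2c(-c3ccc(F)cc3F)cc(Cl)cn12`) carries 2,4-difluorophenyl in place of 3-(hydroxymethyl)phenyl on an aromatic carbon, ortho to a fused ring: 2,4-difluorophenyl in place of 3-(hydroxymethyl)phenyl on an aromatic carbon. Among the measured compounds shown here, only one measured step bears on this change, a step that the two limits leave unreadable from compound 1 to compound 2, in which 3-(hydroxymethyl)phenyl replaced 4-cyanophenyl. That step offers no size to carry over, so any forecast here is loose. A modest step towards lower numbers in this assay is expected, rather than a large one. The expected change is an at least 1.6-fold lower number from compound 2 to compound 3 (0.22 log units; that floor lies within the scatter). For compound 3 the estimated value is 15000 nM, with an expected range from 4000 nM to 50000 nM.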

Compound 3, half-maximal cytotoxic concentration: > 7800 nM
Compound 3 ended at the assay's limit; the forecaster's own chance of this, stated with the estimate: 60%; the middle value does not contradict the limit.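

In this assay compound 3 gives > 7800 nM, which is a limit and not a number. Among the compounds shown here, with compound 1 and compound 2 also at limits, no step among the three compounds can be read. The compounds shown leave open how far the 2,4-difluorophenyl, 3-(hydroxymethyl)phenyl and 4-cyanophenyl compounds actually differ in this assay.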